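The compounds below may be only part of what the source reports. "The series", "measured", "known", "first", "only" and "open" are said of these compounds alone.

In a functional assay on HepG2 cells (Homo sapiens) for cytotoxicity, read by MTT assay, with a stated time of 48 h (on this read-out lower numbers stand for stronger inhibition and higher numbers for weaker inhibition), compound 2, `CCCCCCCCCCCCCCNC(=O)[C@@H](NC(=O)c1ccccc1)[C@@H](C)O`, gives 54200 nM. Of the two numbers available here this is the highest; compound 3, `CCCCCCCCCCCCCCNC(=O)[C@@H](NC(=O)c1nccc2ccccc12)[C@@H](C)O`, gives 28600 nM, and the change from the one to the other, a 1.9-fold lower number from compound 2 to compound 3 (0.28 log units; within the scatter), stays within the scatter, so the two cannot be placed in order. Compound 1, `CCCCCCCCCCCCNC(=O)[C@@H](NC(=O)c1ccccc1)[C@@H](C)O`, returns only a limit of the assay, the limit of > 400000 nM in this assay, at which 1 of the 3 values shown sits: in this assay compound 1 gives > 400000 nM. Going from the shorter chain to the longer one, an at least 7.3-fold lower number from compound 1 to compound 2 (0.86 log units; beyond the scatter), is the only step that clearly moves the number.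

Compound 4, `CCCCCCCCCCCCCCNC(=O)[C@@H](NS(=O)(=O)c1ccc(C)cc1)[C@@H](C)O`, differs from compound 2 in one place: (4-methylphenyl)sulfonyl in place of benzoyl on an amine nitrogen. Neither measured step touches this position in the same way. The step from compound 2 to compound 3 exchanges one aromatic group for another on the carbonyl carbon and stays within the scatter; the step from compound 1 to compound 2 lies on the saturated chain. For the measured compounds named here, no measured step therefore bears directly on exchanging benzoyl for (4-methylphenyl)sulfonyl, and no step beyond the scatter is expected. The estimate for compound 4 is 50000 nM, from 15000 nM to 200000 nM, which is expected to be a step of a 1.1-fold lower number from compound 2 to compound 4 (0.04 log units; within the scatter).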

Compound 4, half-maximal inhibitory concentration: 10900 nM
The estimate for compound 4 lay 4.6-fold (0.66 log units) above the measured number; the measured number lies below the stated range.
By their numbers in this assay, from the lowest: compound 4; then compounds 3 and 2 (each within the scatter of the next). At a limit, above all of these: compound 1.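

For the compounds shown here, the group on the amine nitrogen does matter in this assay: putting (4-methylphenyl)sulfonyl in place of benzoyl gives a 5.0-fold lower number from compound 2 to compound 4 (0.70 log units; beyond the scatter), the first change at this end of the molecule to go beyond the scatter. The earlier exchange at this end, a 1.9-fold lower number from compound 2 to compound 3 (0.28 log units; within the scatter), replaced one aromatic group with another on the carbonyl carbon, whereas the new change replaces the carbonyl link itself with a sulfonyl and adds a methyl to a ring that is still six-membered, aromatic and made of carbon only. Nothing in the data shown accounts for this step.

The sulfonyl and the methyl arrive together, so their shares of the step stay unresolved; a plain phenylsulfonyl group on the same nitrogen would separate them, and a methanesulfonyl group would test whether the ring is needed at all. Going by these compounds alone, also open is whether the chain length matters as much with (4-methylphenyl)sulfonyl on the nitrogen as it does with benzoyl, which a dodecyl or a longer chain in place of the one in compound 4 would address.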